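Changing the Amide Substituent and Tolerated Concentration

A few compounds are considered here, and "the series" means these few. Any claim that something is new, unique, unknown or untested is made for them only; others in the source may bear on it.

In an ADME assay on LLC-MK2 cells (Macaca mulatta) for cytotoxicity, read by spectrophotometry and crystal violet staining, with a stated time of 4 days (a higher number here means that more compound is tolerated, a lower number that less compound is tolerated), compound 1 `CC(C)n1ncc2c(C(=O)Nc3ccncc3)cc(-c3cccs3)nc21` gives 6300 nM.
In this assay compound 2 `CC(C)n1ncc2c(C(=O)Nc3ccccc3F)cc(-c3cccs3)nc21` gives 50000 nM.
In this assay compound 3 `CC(C)n1ncc2c(C(=O)Nc3ccccn3)cc(-c3cccs3)nc21` gives > 200000 nM, which is a limit of the measurement rather than a number.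

Compound 3 therefore stands at the top of the three results shown, the only one sitting at that limit (the limit of > 200000 nM in this assay, at which 1 of the 3 values shown sits). Compound 4 `CC(C)n1ncc2c(C(=O)Nc3ccc(F)cc3F)cc(-c3cccs3)nc21` differs from compound 3 in one place: 2,4-difluorophenyl in place of pyridin-2-yl on an amide-type nitrogen. Among the measured compounds shown here, two measured steps bear on this. an at least 4.0-fold higher number from compound 2 to compound 3 (0.60 log units; beyond the scatter) runs in the opposite direction to the change now considered, and a 7.9-fold higher number from compound 1 to compound 2 (0.90 log units; beyond the scatter) shows a higher number for 2-fluorophenyl than for pyridin-4-yl. Reversing the first of these, a lower number is expected for compound 4, a step of about an at least 2.5-fold lower number from compound 3 to compound 4 (0.39 log units; beyond the scatter). The estimate for compound 4 is 80000 nM, with a range from 30000 nM to 200000 nM.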

Compound 4, half-maximal cytotoxic concentration: > 200000 nM
Compound 4: only a limit was reported; the forecaster's own chance of this, stated with the estimate: 25%; at least 2.5-fold (0.39 log units) between middle value and limit.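

In this assay, fluoro in place of hydrogen on an aromatic carbon gives an at least 4.0-fold higher number from compound 2 to compound 4 (0.60 log units; beyond the scatter), so pyridin-2-yl is not the only amide substituent that reaches the top of the range; a ring of carbon only, 2,4-difluorophenyl, does too. Against pyridin-4-yl the change gives an at least 31-fold higher number from compound 1 to compound 4 (1.50 log units; beyond the scatter). Compound 3 and compound 4 each carry a limit rather than a number, so the steps between them cannot be read: the limit of > 200000 nM in this assay, at which 2 of the 4 values shown sit.

On these data alone, whether a phenyl ring carrying methoxy or trifluoromethyl in place of fluoro would also stay at this limit remains open.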